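Compound 2 to compound 4: notes on tolerated concentration

A few compounds are considered here, and "the series" means these few. Any claim that something is new, unique, unknown or untested is made for them only; others in the source may bear on it.

In a toxicity assay on HepG2 2.2.15 cells (Homo sapiens) for cytotoxicity, read by CellTiter-Glo (a higher number here means that more compound is tolerated, a lower number that less compound is tolerated), three compounds have been measured. Going by the values given here, compound 2 `CC1(C)CC(=O)N(c2cnn3c2CN(C(=O)Nc2cc(F)c(F)c(F)c2)C(C2CC2)C3)C1` gives 115000 nM, the only actual number in the set. Compound 1 `C[C@H]1Cn2ncc(N3CC(c4ccccc4)CC3=O)c2CN1S(=O)(=O)Nc1cc(F)c(F)c(F)c1` reads > 2000 nM, which is a limit of the assay and not a number. Compound 3 `C[C@H]1Cn2ncc(N3CC(c4ccccc4)CC3=O)c2CN1CC(=O)Nc1cc(F)c(F)c(F)c1` reads > 2000 nM, which is also a limit. The set therefore shows (the limit of > 2000 nM in this assay, at which 2 of the 3 values shown sit), and compound 2 cannot be ranked against compound 1 or compound 3.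

Compound 4 `O=C1c2ccccc2CN1c1cnn2c1CN(C(=O)Nc1cc(F)c(F)c(F)c1)C(C1CC1)C2` is still unmeasured. It differs from compound 2 at one place: a group of 10 heavy atoms (8 carbon, 1 nitrogen, 1 oxygen; one five-membered non-aromatic ring with 1 hetero atom, one six-membered aromatic ring of carbon only) in place of a group of 8 heavy atoms (6 carbon, 1 nitrogen, 1 oxygen; one five-membered non-aromatic ring with 1 hetero atom), on an aromatic carbon. The 4,4-dimethyl-2-oxopyrrolidin-1-yl group leaves, and a group that adds one six-membered aromatic ring of carbon only enters, on an aromatic carbon.

Among the compounds with values here, no measured pair differs in one place, so the size of this change in this assay cannot be read from the data. The expectation rests on compound 2 at 115000 nM and on the structural change alone. A moderate move towards less compound tolerated is expected, although a change within the usual scatter remains possible. The estimated step is a 1.9-fold lower number from compound 2 to compound 4 (0.28 log units; within the scatter). The expected value for compound 4 is 60000 nM, with an estimated range of 15000 nM to 150000 nM.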

Compound 4, half-maximal cytotoxic concentration: 38500 nM
Estimate against measurement, compound 4: 1.6-fold (0.19 log units) above; the range from low to high includes it.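

In this assay, the series now has its first readable step, a 3.0-fold lower number from compound 2 to compound 4 (0.48 log units; beyond the scatter), on an aromatic carbon. The earlier compounds shown here could not show that this place responds to a change of group, and here the replacement of 4,4-dimethyl-2-oxopyrrolidin-1-yl gives a modest step that lies beyond the scatter. The entering group keeps a five-membered non-aromatic ring with 1 hetero atom and the same counts of hydrogen-bond donors and acceptors, adds a six-membered aromatic ring of carbon only and lacks the 4,4-dimethyl substitution, and this single pair cannot separate those two differences.

Steps involving compound 1 and compound 3 cannot be read, because their entries are limits of the assay and not numbers: the limit of > 2000 nM in this assay, at which 2 of the 4 values shown sit.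

Still open, from the compounds shown here alone, is whether an amine, a carboxylic acid or a longer chain on this aromatic carbon would move the number further, and in which direction.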